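The compounds below may be only part of what the source reports. "The series", "measured", "known", "first", "only" and "open" are said of these compounds alone.

Compound 1 `Cc1nc2cc3c(cc2n1-c1ccccc1)C1CNCC3C1` — in an assay on HEK293 cells for binding affinity to Neuronal acetylcholine receptor; alpha4/beta2 (Homo sapiens) (on this read-out lower numbers stand for stronger inhibition and higher numbers for weaker inhibition), compound 1 gives < 5 nM, which is a limit of the assay rather than a number.
Compound 2 `c1ccc(-n2cnc3cc4c(cc32)C2CNCC4C2)cc1` — in this assay compound 2 gives 0.14 nM.

Compound 1 therefore stands only at a limit in this assay, as the limit of < 5 nM in this assay, at which 1 of the 2 values shown sits, records, so its true value is not known as a number. The step that the limit leaves unreadable from compound 1 to compound 2 is a methyl giving way to hydrogen on an aromatic carbon, and its size cannot be read because compound 1 is a limit.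

Compound 3 `Cc1nc2cc3c(cc2[nH]1)C1CNCC3C1` differs from compound 1 in another place: hydrogen in place of phenyl on an aromatic nitrogen. Among the measured compounds shown here, no measured step touches the phenyl on the ring nitrogen, so the two measured compounds offer no direct guide to its size or direction; both only show that the shared core binds tightly in this assay. The step that the limit leaves unreadable from compound 1 to compound 3 is my estimate, with no expectation of a change beyond the scatter. Compound 3 is expected to give about 1.5 nM in this assay, within a range of 0.15 nM to 15 nM.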

Compound 3, inhibition constant: 0.1 nM
Estimate against measurement, compound 3: 15-fold (1.18 log units) above; the whole stated range lies above it.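

Compound 1 is recorded only as a limit, not a number, so the change from compound 1 to compound 3 has no readable size: the limit of < 5 nM in this assay, at which 1 of the 3 values shown sits. The compounds shown leave open how much replacing phenyl with hydrogen on the aromatic nitrogen actually changes binding.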